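Methylamino in place of amino on the shared core

The compounds below may be only part of what the source reports. "The series", "measured", "known", "first", "only" and "open" are said of these compounds alone.

Measured compounds in a functional assay on the whole organism with Rattus norvegicus as the target, at a dose of 1 mg/kg by the oral route; on this read-out lower numbers stand for a weaker effect and higher numbers for a stronger effect at the one dose given:
compound 1, `Cc1ccc(-c2cc(C)cc(C(=O)Nc3nn[nH]n3)n2)cc1`, 80%
compound 2, `Cc1cc(C(=O)Nc2nn[nH]n2)nc(-c2ccc(C(C)C)cc2)c1`, 34%
compound 3, `Cc1cc(C(=O)Nc2nn[nH]n2)nc(-c2ccc(N)cc2)c1`, 75%

Compound 3 stands second highest of the three; its nearest neighbour is compound 1, a gap within the scatter, while compound 2 lies far below it, as the step of a number 41 percentage points higher from compound 2 to compound 3 (beyond the scatter) shows. Compound 4, `CNc1ccc(-c2cc(C)cc(C(=O)Nc3nn[nH]n3)n2)cc1`, differs from compound 3 by methyl in place of hydrogen on a nitrogen on an aromatic ring.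

Within the data shown here, no measured step alters a group on a nitrogen, so only indirect guides exist. The step of a number 5 percentage points lower from compound 1 to compound 3 (within the scatter) shows that amino and methyl on that aromatic carbon give much the same read-out, whereas a number 46 percentage points lower from compound 1 to compound 2 (beyond the scatter) shows that a larger group there costs heavily. Adding one carbon onto the amino nitrogen is a smaller enlargement than that, so a moderate drop, or none beyond the scatter, is expected.

Compound 4 is therefore estimated at 62%, with a range of 35% to 85%. The expected step is a number 13 percentage points lower from compound 3 to compound 4 (beyond the scatter).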

Compound 4, a percentage reported as inhibition, in the whole organism at one dose (the size of the read-out at that dose, not a potency): 89%
Compound 4: middle estimate off by 27 percentage points, on the low side; the whole stated range lies below it.
By their numbers in this assay, from the lowest: compound 2; then compounds 3, 1 and 4 (each within the scatter of the next, the first and the last beyond it).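

In this assay, among these compounds, a number 14 percentage points higher from compound 3 to compound 4 (beyond the scatter) gives the first view of a change on this nitrogen, and putting methyl in place of hydrogen there raises the read-out rather than lowering it. At the same time, a number 9 percentage points higher from compound 1 to compound 4 (within the scatter) places methylamino level with the methyl of compound 1 on this aromatic carbon. The large step of a number 55 percentage points higher from compound 2 to compound 4 (beyond the scatter) shows that the heavy loss seen with isopropyl does not carry over to methylamino.

The compounds shown leave open whether the gain persists with a longer chain on this nitrogen, as in ethylamino, or with a second methyl, as in dimethylamino. As far as these compounds go, how these compounds would rank at other doses also remains open. No evidence is available to explain the rise from amino to methylamino.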